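A Furan Swapped for a Methylpyrazole on a Shared Core

The source may hold more compounds than are shown below. What is called first, only, known or untested is meant among the compounds shown, and "the series" means these compounds.

Compound 2 `CCN(c1ccc(C#N)c(Cl)c1)c1cc(-c2ccoc2)ccc1C` was tested in a functional assay on CWR22R cells (Homo sapiens) for antiproliferative activity, read by CCK-8 assay, with a stated time of 6 days (on this read-out higher numbers stand for weaker inhibition and lower numbers for stronger inhibition), and gave only a limit of > 30000 nM rather than a number. Two related compounds were also made: compound 1 `Cc1noc(C)c1-c1cccc(Oc2ccc(C#N)c(C(F)(F)F)c2)c1` and compound 3 `Cc1noc(C)c1-c1cccc2c1CCCN2c1ccc(C#N)c(C(F)(F)F)c1`. In this assay compound 1 stands at "not determined" (no result reported) and compound 3 at "not determined" (no result reported), so compound 2 is the only one with any result, and that result is the limit of > 30000 nM in this assay, at which 1 of the 3 values shown sits. Compound 4 `CCN(c1ccc(C#N)c(Cl)c1)c1cc(-c2c[nH]nc2C)ccc1C` differs from compound 2 in one place: 3-methyl-1H-pyrazol-4-yl in place of furan-3-yl on an aromatic carbon. For the measured compounds named here, no measured pair shows what this swap does, so no step beyond the usual scatter is expected in this assay. Compound 4 is estimated at 25000 nM, within a range from 5000 nM to 60000 nM, an expected step of an at least 1.2-fold lower number from compound 2 to compound 4 (0.07 log units; that floor lies within the scatter), with a real chance that only a limit is reported again.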

Compound 4, half-maximal inhibitory concentration: 5380 nM
Beside the measured number, compound 4's estimate is 4.6-fold (0.67 log units) above it, within the range that was stated.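

In this assay, for the compounds shown here, the first measured change at this position, 3-methyl-1H-pyrazol-4-yl in place of furan-3-yl on an aromatic carbon gives an at least 5.5-fold lower number from compound 2 to compound 4 (0.74 log units; beyond the scatter) and so shows that the group on this carbon matters. The size of this step is only a floor, since the value for compound 2 is a limit and not a number: the limit of > 30000 nM in this assay, at which 1 of the 4 values shown sits.

The compounds shown do not separate the methyl group from the hydrogen-bond donor of the pyrazole ring. From the compounds shown here alone, how an amine or a carboxylic acid on this carbon would read also stays open.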